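The source may hold more compounds than are shown below. What is called first, only, known or untested is meant among the compounds shown, and "the series" means these compounds.

Measured so far in a functional assay on HCT-116 cells (Homo sapiens) for inhibition, read by MTT assay, with a stated time of 72 h; a higher number here means a weaker inhibitor, a lower number a stronger inhibitor:
compound 1 `CCOC(=O)c1oc2ccc(N(Cc3ccccc3)S(=O)(=O)c3cccc(Br)c3)cc2c1C` gives > 40000 nM, which is a limit of the assay rather than a number.
compound 2 `CCOC(=O)c1oc2ccc(N(Cc3ccccc3)S(=O)(=O)c3ccc(C(F)(F)F)cc3)cc2c1C` gives 26700 nM.
compound 3 `CCOC(=O)c1oc2ccc(N(Cc3ccccc3)S(=O)(=O)c3ccc(Cl)cc3)cc2c1C` gives 4860 nM.

Compound 3 holds the lowest number among the measured compounds in this assay, with compound 2 nearest at a 5.5-fold lower number from compound 2 to compound 3 (0.74 log units; beyond the scatter). Compound 4 `CCOC(=O)c1oc2ccc(N(Cc3ccccc3)S(=O)(=O)c3cccc(Cl)c3)cc2c1C` differs from compound 3 by 3-chlorophenyl in place of 4-chlorophenyl on a sulfonyl sulfur. The step that bears on it is an at least 8.2-fold lower number from compound 1 to compound 3 (0.91 log units; beyond the scatter), where the 4-chlorophenyl compound reached a number and the 3-bromophenyl compound only the limit (the limit of > 40000 nM in this assay, at which 1 of the 3 values shown sits). Returning a halogen to the 3-position of the phenyl is therefore expected to raise the number in this assay, by roughly a 4.1-fold higher number from compound 3 to compound 4 (0.61 log units; beyond the scatter). Compound 4 is estimated at 20000 nM, within 6000 nM to 60000 nM.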

Compound 4, half-maximal inhibitory concentration: > 40000 nM
Compound 4 ended at the assay's limit (the forecaster's own chance of this, stated with the estimate: 30%); middle value at least 2.0-fold (0.30 log units) away from the limit.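

Moving the chlorine, with the same atoms joined differently, gives an at least 8.2-fold higher number from compound 3 to compound 4 (0.91 log units; beyond the scatter) in this assay, so 4-chlorophenyl and 3-chlorophenyl on the sulfonyl sulfur are clearly separated. Putting 3-chlorophenyl in place of 4-(trifluoromethyl)phenyl gives an at least 1.4-fold higher number from compound 2 to compound 4 (0.17 log units; that floor lies within the scatter), and the step from compound 1 cannot be read. Compound 1 and compound 4 both end at a limit rather than a number: the limit of > 40000 nM in this assay, at which 2 of the 4 values shown sit.

As far as these compounds go, how the two 3-halogenated compounds truly compare remains unknown. From the compounds shown here alone, whether 4-bromophenyl or 4-aminophenyl on the sulfonyl sulfur would match compound 3 also stays open.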